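The compounds below may be only part of what the source reports. "The series", "measured", "known", "first", "only" and "open" are said of these compounds alone.

Measured in a functional assay on KB cells (Homo sapiens) for inhibition; on this read-out lower numbers stand for stronger inhibition and higher numbers for weaker inhibition:
Compound 1 `OCC(CO)OCn1cnc2cc(Cl)c(Cl)cc21` gives > 100000 nM, a limit of the assay.
Compound 2 `CNc1nc2c(Cl)c(Cl)ccc2n1COC(CO)CO` gives > 100000 nM, likewise a limit.
Compound 3 `OCC(CO)OCn1c(S)nc2cc(Cl)c(Cl)cc21` gives > 100000 nM, again a limit.

Compound 2 thus stands at the limit of this assay, and the two further values shown are limits as well, so no order among the three compounds can be read. Within the data shown here, the only step between measured compounds that differ in a single place, a step that the two limits leave unreadable from compound 1 to compound 3, has no readable size because both of its ends sit at the limit of > 100000 nM in this assay, at which 3 of the 3 values shown sit.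

Compound 4 `OCC(CO)OCn1c(S)nc2c(Cl)c(Cl)ccc21` differs from compound 2 by sulfanyl in place of methylamino on an aromatic carbon. Among the measured compounds shown here, no measured step concerns this exchange; the step from compound 1 to compound 3 addresses a different change and is itself unreadable. Nothing in the series therefore points to a shift in this assay in either direction, and with all three values at the limit of > 100000 nM in this assay, at which 3 of the 3 values shown sit, a fourth limit is the likely outcome. Compound 4 is expected to give about 100000 nM, within 30000 nM to 300000 nM, most probably reported only as a limit. The estimated step is a number no higher from compound 2 to compound 4 (the limit leaves the size open), of no readable direction.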

Compound 4, half-maximal inhibitory concentration: > 100000 nM
Compound 4: no number, only a limit (the forecaster's own chance of this, stated with the estimate: 85%); the middle value lies on the limit itself.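

Compound 4 also sits at a limit, so the exchange between compound 2 and compound 4 gives no readable step, and neither does any other pair: the limit of > 100000 nM in this assay, at which 4 of the 4 values shown sit.

The compounds shown leave open whether any exchange on the shared core changes inhibition at all.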